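Dichlorobenzyl Variants of a Tetrafluorophenoxymethyl Ketone Series

The source may report more compounds than this note shows. Statements on the series, on what has been measured and on what is new or still open speak of the compounds shown alone.

Measured compounds:
- compound 1, `Cc1cccc(CNC(=O)C(=O)N[C@@H](C)C(=O)N[C@@H](CC(=O)O)C(=O)COc2c(F)c(F)cc(F)c2F)c1`: 127 nM
- compound 2, `C[C@H](NC(=O)C(=O)NCc1cc(Cl)ccc1Cl)C(=O)N[C@@H](CC(=O)O)C(=O)COc1c(F)c(F)cc(F)c1F`: 4.3 nM

In a functional assay on Jurkat cells (Homo sapiens) (a higher number here means a weaker inhibitor, a lower number a stronger inhibitor), compound 1 gives 127 nM, the highest of the two numbers shown; its nearest neighbour is compound 2, which in this assay gives 4.3 nM. Within the data shown here, the one measured step in this set is a 30-fold lower number from compound 1 to compound 2 (1.47 log units; beyond the scatter).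

Compound 3, `C[C@H](NC(=O)C(=O)NCc1c(Cl)cccc1Cl)C(=O)N[C@@H](CC(=O)O)C(=O)COc1c(F)c(F)cc(F)c1F`, is the unmeasured member. It differs from compound 1 in one place: 2,6-dichlorophenyl in place of 3-methylphenyl on a saturated chain carbon bound to an amide-type nitrogen. Among the measured compounds shown here, the only step that bears on this change is the one from compound 1 to compound 2, where a dichlorophenyl group also replaced the 3-methylphenyl group at the same saturated chain carbon and the number fell by a large margin, well beyond the scatter. Since compound 3 carries a dichlorophenyl group in a different arrangement, the size of the effect is less certain, but a drop in the same direction is expected, because the step of a 30-fold lower number from compound 1 to compound 2 (1.47 log units; beyond the scatter) was large. The expected step for compound 3 is therefore a 13-fold lower number from compound 1 to compound 3 (1.10 log units; beyond the scatter), and compound 3 is estimated at 10 nM, with a likely range from 3 nM to 40 nM.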

Compound 3, half-maximal inhibitory concentration: 110 nM
The estimate for compound 3 lay 11-fold (1.04 log units) below the measured number, outside the stated range (above it).
By their numbers in this assay, from the lowest: compound 2; then compounds 3 and 1 (each within the scatter of the next).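

In this assay, carrying two chlorine atoms on the ring is not enough on its own at this saturated chain carbon bound to an amide-type nitrogen: putting 2,6-dichlorophenyl in place of 3-methylphenyl gives a 1.2-fold lower number from compound 1 to compound 3 (0.06 log units; within the scatter) and leaves compound 3 level with compound 1. The arrangement of the chlorine atoms is what separates the two dichlorophenyl compounds, since 2,6-dichlorophenyl in place of 2,5-dichlorophenyl gives a 26-fold higher number from compound 2 to compound 3 (1.41 log units; beyond the scatter) in this same assay. Among these three compounds, the large step seen earlier therefore belongs to 2,5-dichlorophenyl specifically and not to dichlorophenyl groups as a class, and no accompanying measurement accounts for the gap between the two arrangements.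

The compounds shown leave open whether the low number of compound 2 needs chlorine at all, or whether a methyl, methoxy or trifluoromethyl group in the same 2,5-pattern on the phenyl ring would give a similar result. They also leave open whether a longer chain between the phenyl ring and the amide-type nitrogen would keep the gap between the two dichlorophenyl arrangements.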